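This account rests on a few compounds, and the source may have more. Where it says the series, first, only, none or still open, it means among the compounds named here.

Measured in a functional assay on Bel-7402 cells (Homo sapiens) for antiproliferative activity, read by MTT assay, with a stated time of 48 h; a higher number here means a weaker inhibitor of growth, a lower number a stronger inhibitor of growth:

- Compound 1 `COc1ccc(/C=C2\Cc3c(cc(OC)c(OC)c3OC)C2=O)cc1Br`: 563 nM
- Compound 2 `COc1cc(/C=C2\Cc3cc(OC)c(OC)c(OC)c3C2=O)cc(OC)c1OC`: > 10000 nM
- Compound 3 `COc1cc2c(cc1O)C(=O)/C(=C/c1ccc(OC)c(OC)c1OC)C2`: 9650 nM

The result for compound 2, > 10000 nM, is a limit of the assay and not a number. That leaves two true numbers to compare. Compound 3 gives 9650 nM, the higher of the two and so the weaker growth inhibition. Compound 1 gives 563 nM, and the gap between the two lies well beyond the usual scatter.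

The next compound is compound 4 `COc1cc2c(cc1OC)C(=O)/C(=C/c1ccc(OC)c(OC)c1OC)C2`. It differs from compound 3 in a single place: methyl in place of hydrogen on an oxygen on an aromatic ring. This puts methyl in place of hydrogen on an oxygen on an aromatic ring, so a hydroxy becomes a methoxy.

Within the data shown here, no two measured compounds differ by this change alone, so the expectation in this assay is a loose one. Compound 1, with no hydroxy, reaches 563 nM, which gives a slight lean towards a lower number. Compound 2 also has no hydroxy, and its result is the limit > 10000 nM, so that lean stays weak. Overall, no step beyond the scatter is expected.

The estimated step runs a 1.4-fold lower number from compound 3 to compound 4 (0.14 log units; within the scatter). For compound 4 the expected value is 7000 nM, with an estimated range of 2000 nM to 15000 nM.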

Compound 4, concentration for 50% growth inhibition: > 10000 nM
Compound 4: no number, only a limit (the forecaster's own chance of this, stated with the estimate: 35%); middle value at least 1.4-fold (0.15 log units) away from the limit.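

Compound 4 gives > 10000 nM, which is a limit of the assay and not a number. Among these compounds, this is the first pair of measured compounds that differ in one place only, and in this assay the change from hydroxy to methoxy on this aromatic ring gives an at least 1.0-fold higher number from compound 3 to compound 4 (0.01 log units; that floor lies within the scatter). Putting methyl on this oxygen therefore brings no lower number, something the earlier compounds could not show, but the true size of the step stays unknown, and compound 4 may lie close to compound 3 or far from it: the limit of > 10000 nM in this assay, at which 2 of the 4 values shown sit.

The compounds shown leave open what other groups at this place would do, such as an ethoxy with its longer chain, an amine in place of the hydroxy, or a carboxylic acid on a short chain attached to this oxygen. They also leave open whether the same change from hydroxy to methoxy would give a similar result in a compound that starts from a much lower number than compound 3, where the step could be read in full.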